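A few compounds are considered here, and "the series" means these few. Any claim that something is new, unique, unknown or untested is made for them only; others in the source may bear on it.

Measured compounds in an ADME assay on HEK-293T cells (Homo sapiens) for cytotoxicity, read by CCK-8 assay, with a stated time of 48 h; a higher number here means that more compound is tolerated, a lower number that less compound is tolerated:

Compound 1, `CCOc1ccccc1NC(=O)CSc1c[nH]c2c(Cl)cccc12`, gives > 100000 nM, which is a limit of this assay and not a number.
Compound 2, `CCOc1ccccc1NC(=O)CSc1c[nH]c2c(OC)cccc12`, gives > 100000 nM, again a limit.
Compound 3, `CCOc1ccccc1NC(=O)CSc1c[nH]c2cc(Cl)ccc12`, gives > 100000 nM, also a limit.

All three readings sit at the limit of > 100000 nM in this assay, at which 3 of the 3 values shown sit, so none of the compounds is distinguished from another here. Compound 1 and compound 2 differ by one change, (methoxy in place of chloro on an aromatic carbon), and the step that the two limits leave unreadable from compound 1 to compound 2 cannot be read because both values are limits. Compound 1 and compound 3 share the same atoms joined differently; the difference between the two cores is not broken down here.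

Compound 4, `CCOc1ccccc1NC(=O)CSc1c[nH]c2cc(OC)ccc12`, is not yet measured. It differs from compound 3 by methoxy in place of chloro on an aromatic carbon. This is the same kind of change as that from compound 1 to compound 2, but the place differs: in compound 1 the group stands ortho to a fused ring and meta to a fused ring, whereas in compound 3 it stands meta to a fused ring and para to a fused ring.

For compound 4 a step that the limit leaves unreadable from compound 3 to compound 4 is expected, resting on the fact that every measured compound sits at the limit of > 100000 nM in this assay, at which 3 of the 3 values shown sit. Compound 4 is therefore estimated at 150000 nM, most likely reported only as a limit again.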

Compound 4, half-maximal cytotoxic concentration: 88200 nM
Estimate against measurement, compound 4: 1.7-fold (0.23 log units) above, within the range that was stated.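

On the core that carries the group meta to a fused ring and para to a fused ring, methoxy in place of chloro gives, in this assay, an at least 1.1-fold lower number from compound 3 to compound 4 (0.05 log units; that floor lies within the scatter). Among the compounds shown here, this floor shows only that a measured number appears on this core, and it does not establish a real change in how much compound is tolerated. On the other core, both readings for the same change are limits, so that step cannot be read and the result cannot be said to carry from one core to the other or to differ between them: the limit of > 100000 nM in this assay, at which 3 of the 4 values shown sit.

The compounds shown leave open whether an amine or a carboxylic acid in place of chloro on the same aromatic carbon would give a number clear of the limit on either core. They also leave open whether a longer chain in place of methoxy would give a step beyond the scatter in this assay.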